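The compounds below may be only part of what the source reports. "The series", "measured", "known", "first", "only" and "open" are said of these compounds alone.

Measured so far in a functional assay on the whole organism (strain Sprague-Dawley) for inhibition, with Rattus norvegicus as the target, with a stated time of 10 min; on this read-out lower numbers stand for an effect already at smaller amounts and higher numbers for an effect only at larger amounts of compound:
compound 1 `CCOC(=O)c1cnc(-c2cc(N)ccc2OCC)[nH]c1=O` gives 0.5 mg/kg
compound 2 `CCOC(=O)c1cnc(-c2cc(N(C)C)ccc2OCC)[nH]c1=O` gives "not determined" (no result reported)

Compound 2 has no number to stand on. In this assay, from the compounds shown here alone, compound 2 is reported as "not determined" (no result reported) and no result is given, so its place relative to compound 1 stays unknown. The next compound is compound 3 `CCOC(=O)c1cnc(-c2cc(S(N)(=O)=O)ccc2OCC)[nH]c1=O`, which keeps the shared core and changes one group (sulfamoyl in place of dimethylamino on an aromatic carbon). In words, sulfamoyl stands in place of dimethylamino on an aromatic carbon, para to an ethoxy group. For the measured compounds named here, no measured step between any two compounds exists here, so the data do not show what such a replacement does. The only anchor for an expectation is compound 1 at 0.5 mg/kg in this assay. From that anchor, a modest step toward larger doses is expected, though it may not exceed the usual scatter, and the uncertainty is wide. For compound 3 the estimated dose in this assay is 1 mg/kg, with an expected range from 0.2 mg/kg to 5 mg/kg.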

Compound 3, dose for 50% inhibition: 50 mg/kg
For compound 3 the middle estimate is 50-fold (1.70 log units) below the measured one; the whole stated range lies below it.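

In this assay the aromatic carbon para to an ethoxy group proves highly sensitive to what it carries: sulfamoyl in place of amino gives a 100-fold higher number from compound 1 to compound 3 (2.00 log units; beyond the scatter) and so provides the first measured sign that the group at this place matters for the dose needed. For the compounds shown here, compound 2 carries dimethylamino at the same place but has no reported result, so the steps involving compound 2 cannot be read, and the single readable step rests on compound 1 and compound 3 alone. No accompanying measurement bears on this change, so the data offer no account of why the number climbs so far.

The compounds shown leave open whether amino is unusually favourable at this place or sulfamoyl unusually poor, and a methylsulfonyl group, an acetamide or a carboxylic acid at the same carbon would help to separate those two readings. They also leave open whether the step would keep its size with a different chain in place of the ethoxy group or with a carboxylic acid in place of the ethyl ester.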